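Sulfonyl Aryl Exchange in a Cytotoxicity Series

A few compounds are considered here, and "the series" means these few. Any claim that something is new, unique, unknown or untested is made for them only; others in the source may bear on it.

Three compounds have been measured so far:
compound 1 `CC1CCN(C2CCN(S(=O)(=O)c3ccc(OCc4ccccc4)cc3)CC2)CC1`: > 5000 nM
compound 2 `Cc1cc(C)c(S(=O)(=O)N2CCC(C(=O)N3CCC(C)CC3)CC2)c(C)c1`: > 5000 nM
compound 3 `Cc1ccc(S(=O)(=O)N2CCC(N3CCC(C)CC3)CC2)cc1C`: > 5000 nM

In an ADME assay on HCT-116 cells (Homo sapiens) for cytotoxicity, read by CellTiter-Glo, with a stated time of 72 h (on this read-out lower numbers stand for stronger inhibition and higher numbers for weaker inhibition), compound 1 gives > 5000 nM, a limit of the assay rather than a number. Compound 2 likewise reaches only the limit > 5000 nM. Compound 3 stands at the same place: its value of > 5000 nM is a limit and not a measured number. Thus the limit of > 5000 nM in this assay, at which 3 of the 3 values shown sit, holds for every value in hand, and nothing on these numbers sets compound 3 apart from compound 1 or compound 2.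

Compound 4 `COc1cccc(S(=O)(=O)N2CCC(N3CCC(C)CC3)CC2)c1` has not yet been measured in this assay. It differs from compound 3 in one place: 3-methoxyphenyl in place of 3,4-dimethylphenyl on a sulfonyl sulfur. Among the measured compounds shown here, no measured pair in this set shows what such an exchange does, so the expectation rests only on where compound 3 stands. All three values in hand reach the limit. Compound 4 is expected to do the same, and the expected step that the limit leaves unreadable from compound 3 to compound 4 is expected to lie within the usual scatter. Compound 4 is therefore estimated at 8000 nM, with a range from 3000 nM to 30000 nM, most likely reported again as a limit.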

Compound 4, half-maximal inhibitory concentration: > 5000 nM
Compound 4: no number, only a limit; the forecaster's own chance of this, stated with the estimate: 85%; the middle value is on the limit's open side.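

Compound 3 and compound 4 both reach only a limit and give no number, so no step can be read between them: the limit of > 5000 nM in this assay, at which 4 of the 4 values shown sit.

The compounds shown leave open what the exchange of 3,4-dimethylphenyl for 3-methoxyphenyl does to the value, and whether any compound of this kind gives a measured number in this assay.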